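The source may hold more compounds than are shown below. What is called first, only, known or untested is meant among the compounds shown, and "the series" means these compounds.

Of the compounds shown here, two from this set have so far been tested in a functional assay on Hs-578T cells (Homo sapiens) for inhibition, read by sulforhodamine B assay, with a stated time of 48 h; a lower number here means a stronger inhibitor of growth, a higher number a weaker inhibitor of growth. Compound 1 `CCOC(=O)[C@H](CCC(=O)O)NC(=O)c1ccc(Oc2nc3cc(N)cc(N)c3nc2-c2ccccc2)cc1` and compound 2 `COc1ccc(Sc2nc3cc(N)cc(N)c3nc2-c2ccccc2)cc1` share a core and differ in the group attached to it. In this assay compound 1 gives < 100000 nM, which is a limit of the assay rather than a number. Compound 2 gives < 100000 nM in this assay, again a limit and not a number. Where compound 2 stands is therefore summed up by the limit of < 100000 nM in this assay, at which 2 of the 2 values shown sit. Compound 3 `Nc1cc(N)c2nc(-c3ccccc3)c(Sc3ccc(F)cc3)nc2c1` has not yet been measured. It differs from compound 2 by fluoro in place of methoxy on an aromatic carbon. Among the measured compounds shown here, no step between two measured compounds is available to show how such a change moves the read-out, so no shift beyond the usual scatter is expected in either direction. The estimated step that the limit leaves unreadable from compound 2 to compound 3 reflects that expectation. Compound 3 is expected to give about 30000 nM in this assay, within a range from 3000 nM to 100000 nM, with a fair chance that only a limit is again reported.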

Compound 3, concentration for total growth inhibition: 61700 nM
Estimate against measurement, compound 3: 2.1-fold (0.31 log units) below; low and high end bracket the measured number.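

Compound 2 has only a limit of the assay in this assay, so the change from compound 2 to compound 3 gives no readable step: the limit of < 100000 nM in this assay, at which 2 of the 3 values shown sit.

The compounds shown leave open how far fluoro in place of methoxy moves growth inhibition, or whether it moves it at all.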